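This account rests on a few compounds, and the source may have more. Where it says the series, first, only, none or still open, it means among the compounds named here.

Three measured compounds share one core, and all three are known in the same assay:

Compound 1, `CNc1nc(N)nc2c1ncn2/C=C1/CC1(CO)CO`, gives > 20000 nM in an ADME assay on CCRF-HSB-2 cells (Homo sapiens) for cytotoxicity, with a stated time of 7 days; a higher number here means that more compound is tolerated, a lower number that less compound is tolerated.
Compound 2, `C=CCOc1nc(N)nc2c1ncn2/C=C1/CC1(CO)CO`, gives > 20000 nM.
Compound 3, `CN(C)c1nc(N)nc2c1ncn2/C=C1/CC1(CO)CO`, gives > 20000 nM.

Each of these values is a limit of this assay and not a number; all three sit at the same place, (the limit of > 20000 nM in this assay, at which 3 of the 3 values shown sit). Compound 1 therefore stands only at a limit, and the same holds for compound 2 and for compound 3. Going by these compounds, the three steps between them, a step that the two limits leave unreadable from compound 1 to compound 2, a step that the two limits leave unreadable from compound 1 to compound 3 and a step that the two limits leave unreadable from compound 2 to compound 3, cannot be read from two limits, so their sizes remain unknown.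

Compound 4, `Nc1nc(NCc2ccccc2)c2ncn(/C=C3/CC3(CO)CO)c2n1`, has not yet been measured. It differs from compound 1 by phenyl in place of hydrogen on a saturated chain carbon bound to a nitrogen on an aromatic ring. The measured steps that bear on this change are the two that start from compound 1, and both are unreadable, so they give neither a direction nor a size. What the three values do show is that a change on a nitrogen on an aromatic ring and a change on an aromatic carbon each left the compound at the limit. Compound 4 is therefore expected to stay at that limit as well, with the step that the limit leaves unreadable from compound 1 to compound 4 expected to lie within the scatter. The estimate for compound 4 is 30000 nM, between 10000 nM and 100000 nM.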

Compound 4, half-maximal cytotoxic concentration: > 20000 nM
Compound 4 gave a limit, no number; the forecaster's own chance of this, stated with the estimate: 85%; the middle value is on the limit's open side.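

In this assay compound 4 gives > 20000 nM, which is a limit and not a number. Its steps from compound 1, compound 2 and compound 3 therefore cannot be read, and all four compounds stand together: the limit of > 20000 nM in this assay, at which 4 of the 4 values shown sit.

The compounds shown leave open where the actual half-maximal cytotoxic concentration of each lies, and whether the four differ at all.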